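This account rests on a few compounds, and the source may have more. Where it says the series, first, only, none or still open, it means among the compounds named here.

Compound 1 `O=C(Oc1ccc([N+](=O)[O-])cc1)N1CCN(S(=O)(=O)c2ccc(C3CCCCC3)cc2)CC1` is a sulfonylpiperazine carbamate bearing a cyclohexyl group; in an assay on isolated protein for inhibition of Fatty-acid amide hydrolase 1 (Homo sapiens), read by fluorescence (on this read-out lower numbers stand for stronger inhibition and higher numbers for weaker inhibition), compound 1 gives 333 nM. Compound 2 `CCCCc1ccc(S(=O)(=O)N2CCN(C(=O)Oc3ccc([N+](=O)[O-])cc3)CC2)cc1` keeps the shared core and in this assay compound 2 gives 179 nM. Among the compounds with values here, the only measured step, a 1.9-fold lower number from compound 1 to compound 2 (0.27 log units; within the scatter), replaces one group on the same aromatic carbon, and its size does not exceed the scatter, so compound 2 and compound 1 cannot be told apart on these numbers. Compound 3 `O=C(Oc1ccc([N+](=O)[O-])cc1)N1CCN(S(=O)(=O)c2ccc(Oc3ccccc3Cl)cc2)CC1` differs from compound 2 by 2-chlorophenoxy in place of butyl on an aromatic carbon, again a swap at that aromatic carbon. Within the data shown here, the one comparable step, a 1.9-fold lower number from compound 1 to compound 2 (0.27 log units; within the scatter), was small, and nothing measured involves the 2-chlorophenoxy group itself, so no change beyond the scatter is expected in either direction. Compound 3 is therefore estimated at 220 nM, with a range from 50 nM to 900 nM, meaning an expected step of a 1.2-fold higher number from compound 2 to compound 3 (0.09 log units; within the scatter).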

Compound 3, half-maximal inhibitory concentration: 1150 nM
For compound 3 the middle estimate is 5.2-fold (0.72 log units) below the measured one; the measured number lies above the stated range.
By their numbers in this assay, from the lowest: compounds 2 and 1 (each within the scatter of the next); then compound 3.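

This position is not indifferent to what it carries. In this assay, 2-chlorophenoxy in place of butyl gives a 6.4-fold higher number from compound 2 to compound 3 (0.81 log units; beyond the scatter), and 2-chlorophenoxy in place of cyclohexyl gives a 3.5-fold higher number from compound 1 to compound 3 (0.54 log units; beyond the scatter), so inhibition is weaker than with either all-carbon group, and both steps lie beyond the scatter, unlike the step between those two groups. No measurement available here bears on the reason for this weakening.

The entering group brings an oxygen, an aromatic ring and a chlorine together, so the compounds shown cannot say which of these parts accounts for the step. A plain phenoxy group without the chlorine, or a phenyl group without the oxygen, would separate them, while an amine or a carboxylic acid on this carbon remains an open case.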